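The compounds below may be only part of what the source reports. "The series", "measured", "known", "first", "only" and "open" are said of these compounds alone.

Measured in a functional assay on HEK293 cells for agonist activity at G-protein coupled receptor 39 (Homo sapiens), read by scintillation proximity assay and inositol phosphate accumulation, with a stated time of 75 min; on this read-out lower numbers stand for an effect already at smaller amounts and higher numbers for an effect only at larger amounts of compound:
compound 1 `Cc1nn(-c2ncnc3nc[nH]c23)c2c1C(C(=O)NCc1ccccc1)CC(=O)N2` gives 2930 nM
compound 2 `Cc1nn(-c2ncnc3nc[nH]c23)c2c1C(OCc1ccc(C#N)cc1)CC(=O)N2` gives 60 nM
compound 3 `Cc1nn(-c2ncnc3nc[nH]c23)c2c1C(OCCn1nccc1C)CC(=O)N2` gives 1620 nM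

On the numbers shown, compound 3 stands second highest of three: near compound 1, with a 1.8-fold lower number from compound 1 to compound 3 (0.26 log units; within the scatter), and far from compound 2, with a 27-fold higher number from compound 2 to compound 3 (1.43 log units; beyond the scatter). For the measured compounds named here, the one large step in the set, a 49-fold lower number from compound 1 to compound 2 (1.69 log units; beyond the scatter), likewise exchanges the whole side group on the saturated ring carbon.

Compound 4 `Cc1nn(-c2ncnc3nc[nH]c23)c2c1C(OCCn1cccn1)CC(=O)N2` differs from compound 3 by hydrogen in place of methyl on an aromatic carbon. None of the three measured steps touches this methyl; all swap entire side groups, so nothing in the data bears directly on the change. For compound 4 the expected step is a 1.0-fold lower number from compound 3 to compound 4 (0.01 log units; within the scatter), within the scatter. For compound 4 the estimate in this assay is 1600 nM, in the range 600 nM to 4500 nM.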

Compound 4, half-maximal effective concentration: 2270 nM
Estimate against measurement, compound 4: 1.4-fold (0.15 log units) below; the measured number falls inside the stated range.
By their numbers in this assay, from the lowest: compound 2; then compounds 3, 4 and 1 (each within the scatter of the next).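

Hydrogen in place of methyl on this aromatic carbon of the five-membered ring gives no shift beyond the scatter in this assay (a 1.4-fold higher number from compound 3 to compound 4 (0.15 log units; within the scatter)), so this methyl is not needed to hold the number. The unsubstituted 1H-pyrazol-1-yl side group stays far from the 4-cyanophenyl compound (a 38-fold higher number from compound 2 to compound 4 (1.58 log units; beyond the scatter)) and within the scatter of the benzylcarbamoyl compound (a 1.3-fold lower number from compound 1 to compound 4 (0.11 log units; within the scatter)). No supporting data explain this result. Open, going by these compounds, is whether ethyl or an amine on this aromatic carbon, or a 3-(1H-pyrazol-1-yl)propoxy group in place of 2-(1H-pyrazol-1-yl)ethoxy, would move the number.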